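Chlorophenyl Amide in Place of Morpholine on a Caffeate Ester

The compounds below may be only part of what the source reports. "The series", "measured", "known", "first", "only" and "open" are said of these compounds alone.

In a functional assay on HeLa cells (Homo sapiens) for cytotoxicity, read by MTT assay, with a stated time of 72 h (a higher number here means a weaker inhibitor, a lower number a stronger inhibitor), compound 1 `CCOc1ccc(COc2c(OC)cc(/C=C/C(=O)OCC(=O)Nc3ccccc3)cc2OC)cc1` gives > 200000 nM, which is a limit of the assay and not a number. Compound 3 `COc1ccc(NC(=O)COC(=O)/C=C/c2cc(OC)c(OCc3ccccc3)c(OC)c2)cc1` likewise reaches only the limit of > 200000 nM. Compound 2 `O=C(COC(=O)/C=C/c1ccc(O)c(O)c1)NN1CCOCC1` stands at the same limit, > 200000 nM, so its place among the numbers shown is simply one of the three values that sit at the limit of > 200000 nM in this assay, at which 3 of the 3 values shown sit. Compound 4 `O=C(COC(=O)/C=C/c1ccc(O)c(O)c1)Nc1ccc(Cl)cc1` differs from compound 2 by 4-chlorophenyl in place of morpholin-4-yl on an amide-type nitrogen. No step between measured compounds is available, and every measurement shown stops at the same limit. The change from compound 2 to compound 4 is therefore expected to give a step that the limit leaves unreadable from compound 2 to compound 4, with no step beyond the scatter. Compound 4 is estimated at 250000 nM, from 100000 nM to 600000 nM, most likely reported again only as a limit.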

Compound 4, half-maximal inhibitory concentration: 195000 nM
Beside the measured number, compound 4's estimate is 1.3-fold (0.11 log units) above it, within the range that was stated.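

In this assay, for the compounds shown here, compound 4 gives 195000 nM, the only value shown that is a number and not a limit. Compound 2 gives > 200000 nM, which is a limit of the assay. The change from morpholin-4-yl to 4-chlorophenyl on an amide-type nitrogen gives an at least 1.0-fold lower number from compound 2 to compound 4 (0.01 log units; that floor lies within the scatter), and its true size cannot be read because one end of it is a limit: the limit of > 200000 nM in this assay, at which 3 of the 4 values shown sit.

Open, as far as these compounds go, is what a carboxylic acid or an amine in place of the chlorine on that phenyl ring would give. Also open, from the compounds shown here alone, is whether 4-chlorophenyl would bring a number on the core of compound 1.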